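Two Limits, Then an Isopropyl Swap

The source may hold more compounds than are shown below. What is called first, only, known or untested is meant among the compounds shown, and "the series" means these compounds.

In a functional assay on cells (Platelet, Homo sapiens) for inhibition (a higher number here means a weaker inhibitor, a lower number a stronger inhibitor), compound 1 (`CCOC(=O)c1ccc(-c2nn(C)c3ccccc23)cc1`) gives > 10000 nM, which is a limit and not a number. Compound 2 (`CCOC(=O)c1ccc(-c2nn(Cc3ccncc3)c3ccccc23)cc1`) gives > 10000 nM, also a limit. Both compounds therefore stand at the same limit: the limit of > 10000 nM in this assay, at which 2 of the 2 values shown sit. Compound 3 (`CCOC(=O)c1ccc(-c2nn(C(C)C)c3ccccc23)cc1`) has isopropyl in place of (pyridin-4-yl)methyl on an aromatic nitrogen. Among the measured compounds shown here, the only measured step bearing on this change, a step that the two limits leave unreadable from compound 1 to compound 2, has no readable size. The expected step, a step that the limit leaves unreadable from compound 2 to compound 3, is therefore estimated to stay within the scatter, with no direction favoured. Compound 3 is expected at about 15000 nM, with an estimated range of 5000 nM to 40000 nM.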

Compound 3, half-maximal inhibitory concentration: > 10000 nM
Compound 3: only a limit was reported (the forecaster's own chance of this, stated with the estimate: 85%); the middle value lies beyond the limit too.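

Among the compounds shown here, compound 1, compound 2 and compound 3 all sit at the same limit, so no step among them can be read: the limit of > 10000 nM in this assay, at which 3 of the 3 values shown sit.

On these data alone, whether any group on the aromatic nitrogen gives measurable inhibition in this assay stays open.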